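Moving a fluorine around a fused ring: compound 3

The source may hold more compounds than are shown below. What is called first, only, known or untested is meant among the compounds shown, and "the series" means these compounds.

In a functional assay on MCF7 cells (Homo sapiens) for cytotoxicity, read by CellTiter-Glo, with a stated time of 5 days (on this read-out lower numbers stand for stronger inhibition and higher numbers for weaker inhibition), compound 1 `CC/C(=C(/c1ccc(/C=C/C(=O)O)cc1)c1ccc2[nH]ncc2n1)c1ccccc1` gives 33 nM, and compound 2 `CC/C(=C(/c1ccc(/C=C/C(=O)O)cc1)c1ccc2[nH]nc(F)c2c1)c1ccccc1` gives 5 nM. Compound 2 therefore stands as the lowest of the two numbers; the step of a 6.6-fold lower number from compound 1 to compound 2 (0.82 log units; beyond the scatter) shows that exchanging the fused ring on the double-bonded chain carbon changed the result beyond the scatter. Compound 3 `CC/C(=C(/c1ccc(/C=C/C(=O)O)cc1)c1cc(F)c2[nH]ncc2c1)c1ccccc1` keeps every atom of compound 2 but joins them differently: 7-fluoro-1H-indazol-5-yl in place of 3-fluoro-1H-indazol-5-yl on a double-bonded chain carbon bound to an aromatic carbon and a double-bonded chain carbon. Among the measured compounds shown here, no measured step covers a shift of the fluorine within the same fused ring, so the only guide is that this part of the molecule has already proved sensitive, as seen from compound 1 to compound 2. A modest step in this assay, most likely toward a higher number but possibly none beyond the scatter, is expected, a 2.4-fold higher number from compound 2 to compound 3 (0.38 log units; beyond the scatter). Compound 3 is estimated at 12 nM, with a range from 4 nM to 40 nM.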

Compound 3, half-maximal inhibitory concentration: 7.5 nM
Beside the measured number, compound 3's estimate is 1.6-fold (0.20 log units) above it; the range from low to high includes it.
By their numbers in this assay, from the lowest: compounds 2 and 3 (each within the scatter of the next); then compound 1.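

In this assay, moving the fluorine within the fused ring gives a 1.5-fold higher number from compound 2 to compound 3 (0.18 log units; within the scatter) and so makes no clear difference: at this place, on a double-bonded chain carbon bound to an aromatic carbon and a double-bonded chain carbon, 3-fluoro-1H-indazol-5-yl and 7-fluoro-1H-indazol-5-yl cannot be told apart. The advantage over the fused group of compound 1 also holds for the new arrangement, with a 4.4-fold lower number from compound 1 to compound 3 (0.64 log units; beyond the scatter) beyond the scatter, so this advantage does not depend on the fluorine having one of these two placements. No measurement available here explains the result.

As far as these compounds go, it remains open how the plain 1H-indazol-5-yl group would compare, with hydrogen in place of fluorine. That comparison would show whether the fluorine contributes at all, or whether the six-membered ring of carbon only accounts for the difference from compound 1.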